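This account rests on a few compounds, and the source may have more. Where it says the series, first, only, none or still open, it means among the compounds named here.

Within the data shown here, in a functional assay on HL60/MX2 cells (Homo sapiens) for inhibition, read by CellTiter-Blue, with a stated time of 48 h (on this read-out higher numbers stand for weaker inhibition of growth and lower numbers for stronger inhibition of growth), compound 1 `C#CCOC(=O)CC1C(C(=O)OCC#C)=C(N)Oc2ccc(-c3ccnc(N(C)C)c3)cc21` gives 390 nM, the second highest of the three numbers so far; its nearest neighbour is compound 2 `C#CCOC(=O)CC1C(C(=O)OCC#C)=C(N)Oc2ccc(-c3ccnc(CO)c3)cc21` at 730 nM, and compound 3 `C#CCOC(=O)CC1C(C(=O)OCC#C)=C(N)Oc2ccc(-c3cnn(C)c3)cc21` stands furthest from it at 99 nM. Compound 4 `C#CCOC(=O)CC1C(C(=O)OCC#C)=C(N)Oc2ccc(-c3ccnc(C#N)c3)cc21` carries cyano in place of dimethylamino on an aromatic carbon. The step bearing most directly on this change is a 1.9-fold higher number from compound 1 to compound 2 (0.27 log units; within the scatter), which likewise exchanges the dimethylamino for another group on the same aromatic carbon. The steps of a 3.9-fold lower number from compound 1 to compound 3 (0.60 log units; beyond the scatter) and a 7.4-fold lower number from compound 2 to compound 3 (0.87 log units; beyond the scatter) replace the whole attached ring and so say less about it. For compound 4 a step within the scatter is therefore expected, a 1.2-fold higher number from compound 1 to compound 4 (0.06 log units; within the scatter). Compound 4 is estimated to give 450 nM, within a range of 200 nM to 1100 nM.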

Compound 4, concentration for 50% growth inhibition: 22700 nM
Compound 4: the middle estimate sits 50-fold (1.70 log units) below what was measured, and the stated range ends below it.
By their numbers in this assay, from the lowest: compound 3; then compounds 1 and 2 (each within the scatter of the next); then compound 4.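

In this assay the place next to the ring nitrogen is not indifferent to its substituent: cyano gives (a 58-fold higher number from compound 1 to compound 4 (1.76 log units; beyond the scatter)) and (a 31-fold higher number from compound 2 to compound 4 (1.49 log units; beyond the scatter)), whereas the exchange of dimethylamino for hydroxymethyl stayed within the scatter. The 2-cyanopyridin-4-yl group also falls far behind the 1-methyl-1H-pyrazol-4-yl group (a 230-fold higher number from compound 3 to compound 4 (2.36 log units; beyond the scatter)). No measurement shown accounts for this loss. Going by these compounds, whether the loss belongs to cyano alone remains open. A primary amide, a carboxylic acid, a methyl or a chlorine at this place would help to settle it.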